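The source may report more compounds than this note shows. Statements on the series, on what has been measured and on what is new or still open speak of the compounds shown alone.

Of the compounds shown here, three built on one shared core have been tested in a functional assay on HEK293T cells for agonist activity at histamine H2 receptor (Homo sapiens), read by beta-arrestin recruitment; on this read-out higher numbers stand for an effect only at larger amounts of compound and lower numbers for an effect already at smaller amounts. Compound 1 `CCCNC(=O)/N=C(\N)NCCCc1sc(N)nc1C` gives 170 nM, compound 2 `Cc1nc(N)sc1CCCN/C(N)=N/C(=O)NCc1ccccc1` gives 100 nM, and compound 3 `Cc1nc(N)sc1CCCN/C(N)=N/C(=O)Nc1ccccc1` gives 3390 nM, the highest of the three numbers. The change a 1.7-fold lower number from compound 1 to compound 2 (0.23 log units; within the scatter) is small, whereas the steps of a 20-fold higher number from compound 1 to compound 3 (1.30 log units; beyond the scatter) and a 34-fold higher number from compound 2 to compound 3 (1.53 log units; beyond the scatter) are both large. Compound 4 `CCCCCNC(=O)/N=C(\N)NCCCc1sc(N)nc1C` has not yet been measured; it differs from compound 3 by pentyl in place of phenyl on an amide-type nitrogen. This runs opposite to the move from propyl to phenyl seen in a 20-fold higher number from compound 1 to compound 3 (1.30 log units; beyond the scatter), so a large fall in the number is expected. For compound 4 the estimate in this assay is 150 nM, within a range from 50 nM to 450 nM. The expected step is then a 23-fold lower number from compound 3 to compound 4 (1.35 log units; beyond the scatter).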

Compound 4, half-maximal effective concentration: 178 nM
For compound 4 the middle estimate is 1.2-fold (0.07 log units) below the measured one, and the stated range covers the measured number.
By their numbers in this assay, from the lowest: compounds 2, 1 and 4 (each within the scatter of the next); then compound 3.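

Pentyl on the amide-type nitrogen removes the penalty seen with phenyl (a 19-fold lower number from compound 3 to compound 4 (1.28 log units; beyond the scatter)), so a chain this long is tolerated at this position. It also sits level with both earlier compounds (a 1.0-fold higher number from compound 1 to compound 4 (0.02 log units; within the scatter); a 1.8-fold higher number from compound 2 to compound 4 (0.25 log units; within the scatter)), which leaves propyl, pentyl and benzyl indistinguishable here, with only the phenyl of compound 3 standing apart. Nothing available explains why phenyl differs from benzyl.

Still open, from the compounds shown here alone, is whether a chain longer than pentyl keeps this level, and whether an amine or a hydroxyl at the chain end does. Going by these compounds, it is also open whether a two-carbon link to the phenyl ring behaves like benzyl.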